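Swapping one amine on a compound held at a limit

A few compounds are considered here, and "the series" means these few. Any claim that something is new, unique, unknown or untested is made for them only; others in the source may bear on it.

Measured in a functional assay on HeLa cells (Homo sapiens) for inhibition, read by sulforhodamine B assay; on this read-out higher numbers stand for weaker inhibition and lower numbers for stronger inhibition:
Compound 1 `CCCN(CCC)C1=CC(=O)c2nc3n(c2C1=O)[C@H]1OC[C@@H](O)[C@H]1OC3`: > 16000 nM, a limit
Compound 2 `O=C1C=C(N2CCCCC2)C(=O)c2c1nc1n2[C@H]2OC[C@@H](O)[C@H]2OC1`: > 16000 nM, a limit

Compound 2 stands at a limit, > 16000 nM, so a readable step could only run toward stronger inhibition. Among the compounds with values here, the series so far offers only (the limit of > 16000 nM in this assay, at which 2 of the 2 values shown sit). Compound 3 `COc1cccc(NC2=CC(=O)c3nc4n(c3C2=O)[C@H]2OC[C@@H](O)[C@H]2OC4)c1` differs from it as follows: (3-methoxyphenyl)amino in place of piperidin-1-yl on a double-bonded ring carbon. It carries (3-methoxyphenyl)amino in place of piperidin-1-yl on a double-bonded ring carbon. Within the data shown here, the one measured step at this place is a step that the two limits leave unreadable from compound 1 to compound 2, and it supplies no size to carry over. The expected step is an at least 1.4-fold lower number from compound 2 to compound 3 (0.16 log units; that floor lies within the scatter), a modest and uncertain move toward stronger inhibition in this assay. For compound 3 the estimated value is 11000 nM, with an expected range of 3000 nM to 35000 nM.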

Compound 3, half-maximal inhibitory concentration: 4280 nM
The estimate for compound 3 lay 2.6-fold (0.41 log units) above the measured number, and the stated range covers the measured number.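

Within the data shown here, at this position, on a double-bonded ring carbon, (3-methoxyphenyl)amino gives the first readable steps in this assay: an at least 3.7-fold lower number from compound 2 to compound 3 (0.57 log units; beyond the scatter), and an at least 3.7-fold lower number from compound 1 to compound 3 (0.57 log units; beyond the scatter). On these data alone, both steps are floors, so their full size remains unknown. The step between the two saturated amines still cannot be read: the limit of > 16000 nM in this assay, at which 2 of the 3 values shown sit.

The compounds shown do not separate the contributions of the aromatic ring, the methoxy group and the amino hydrogen. They also leave open how a plain phenylamino or a benzylamino group would read here.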